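Urea-ring trifluoromethyl count and cell growth inhibition

The compounds below may be only part of what the source reports. "The series", "measured", "known", "first", "only" and "open" are said of these compounds alone.

Measured so far:
compound 1, `O=C(Nc1cccc(-n2cc(-c3ccncc3)c(-c3cc(O)cc(Cl)c3)n2)c1)Nc1ccc(Cl)c(C(F)(F)F)c1`: 99%
compound 2, `O=C(Nc1cccc(-n2cc(-c3ccncc3)c(-c3cc(O)cc(Cl)c3)n2)c1)Nc1ccc(Cl)c(Cl)c1`: 101%
compound 3, `COc1cc(Cl)cc(-c2nn(-c3cccc(NC(=O)Nc4cc(C(F)(F)F)cc(C(F)(F)F)c4)c3)cc2-c2ccncc2)c1`: 24%

In a functional assay on COLO 205 cells (Homo sapiens) for inhibition, read by sulforhodamine B assay, with a stated time of 48 h, tested at 1 uM (a higher number here means a weaker effect of the compound at the concentration tested, a lower number a stronger effect), compound 3 stands lowest of the three numbers, beyond the scatter from both compound 1 and compound 2, which sit within the scatter of each other. Compound 4, `COc1cc(Cl)cc(-c2nn(-c3cccc(NC(=O)Nc4cccc(C(F)(F)F)c4)c3)cc2-c2ccncc2)c1`, differs from compound 3 in one place: hydrogen in place of trifluoromethyl on an aromatic carbon. For the measured compounds named here, the only measured step, a number 2 percentage points higher from compound 1 to compound 2 (within the scatter), swaps one group for another on the same aromatic ring and lies within the scatter; no measured step removes a trifluoromethyl. Compound 4 is therefore expected to show a weaker effect than compound 3, with a step of a number 31 percentage points higher from compound 3 to compound 4 (beyond the scatter) beyond the scatter. The estimate for compound 4 is 55%, within 20% to 95%.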

Compound 4, a percentage reported as activity, at one concentration (the size of the read-out at that concentration, not a potency): 79%
Compound 4: middle estimate off by 24 percentage points, on the low side; the measured number falls inside the stated range.
By their numbers in this assay, from the lowest: compound 3; then compound 4; then compounds 1 and 2 (each within the scatter of the next).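

Hydrogen in place of one trifluoromethyl, meta to a trifluoromethyl group, gives a large loss of effect in this assay, a number 55 percentage points higher from compound 3 to compound 4 (beyond the scatter). For the compounds shown here, the earlier step, a number 2 percentage points higher from compound 1 to compound 2 (within the scatter), showed no readable change, so this is the first sign that a single group on this ring can move the read-out strongly. No measurement shown gives a reason for the size of this step.

From the compounds shown here alone, whether another group at this position, such as a nitrile or an amine, would keep the effect remains open. No pair shown isolates hydroxy from methoxy on the other ring.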